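A few compounds are considered here, and "the series" means these few. Any claim that something is new, unique, unknown or untested is made for them only; others in the source may bear on it.

Measured so far:
Compound 1, `C/C(=C\CC/C(C)=C/CC[C@@H]1[C@@]2(C)CCC(=O)C(C)(C)[C@H]2CC[C@@]1(C)O)CC/C=C(\C)C(=O)OCc1cn(-c2ccccc2Cl)nn1`. In a functional assay on A549 cells (Homo sapiens) for antiproliferative activity, read by MTT assay, with a stated time of 48 h (on this read-out lower numbers stand for stronger inhibition and higher numbers for weaker inhibition), compound 1 gives > 150000 nM, which is a limit of the assay rather than a number.
Compound 2, `C/C(=C\CC/C(C)=C/CC[C@@H]1[C@@]2(C)CCC(=O)C(C)(C)[C@H]2CC[C@@]1(C)O)CC/C=C(\C)C(=O)OCc1cn(-c2cccc(O)c2)nn1`. In this assay compound 2 gives 42800 nM.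
Compound 3, `C#CCOC(=O)/C(C)=C/CC/C(C)=C/CC/C(C)=C/CC[C@@H]1[C@@]2(C)CCC(=O)C(C)(C)[C@H]2CC[C@@]1(C)O`. In this assay compound 3 gives 45100 nM.

Compound 3 and compound 2 sit close together: a 1.1-fold higher number from compound 2 to compound 3 (0.02 log units; within the scatter). Compound 1 is apart from both, since its value is only a limit, (the limit of > 150000 nM in this assay, at which 1 of the 3 values shown sits).

Compound 4, `C/C(=C\CC/C(C)=C/CC[C@@H]1[C@@]2(C)CCC(=O)C(C)(C)[C@H]2CC[C@@]1(C)O)CC/C=C(\C)C(=O)OCc1cn(-c2ccccc2)nn1`, differs from compound 3 in one place: 1-phenyl-1H-1,2,3-triazol-4-yl in place of ethynyl on a saturated chain carbon bound to an oxygen next to a carbonyl group. For the measured compounds named here, two measured steps bear on this change. Replacing the triazole bearing 2-chlorophenyl by ethynyl gave an at least 3.3-fold lower number from compound 1 to compound 3 (0.52 log units; beyond the scatter), whereas replacing the triazole bearing 3-hydroxyphenyl by ethynyl gave a 1.1-fold higher number from compound 2 to compound 3 (0.02 log units; within the scatter). The phenyl of compound 4 carries neither substituent, so the step is expected to lie between those two outcomes, most likely a modest rise in the number, a 1.4-fold higher number from compound 3 to compound 4 (0.16 log units; within the scatter). Compound 4 is therefore estimated at 65000 nM, within 30000 nM to 150000 nM.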

Compound 4, half-maximal inhibitory concentration: > 150000 nM
Compound 4 gave a limit, no number; the forecaster's own chance of this, stated with the estimate: 30%; at least 2.3-fold (0.36 log units) between middle value and limit.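

In this assay, the unsubstituted 1-phenyl-1H-1,2,3-triazol-4-yl group does not match the ethynyl group it replaces at this place on the saturated chain carbon: an at least 3.3-fold higher number from compound 3 to compound 4 (0.52 log units; beyond the scatter). Replacing the hydroxy of compound 2 by hydrogen on the aromatic carbon has a similar outcome, an at least 3.5-fold higher number from compound 2 to compound 4 (0.54 log units; beyond the scatter), so among the three triazole compounds shown, only the one with the 3-hydroxyphenyl group gives a measured number rather than a limit. Compound 4 gives a limit of the assay, as compound 1 does, so the step between these two cannot be read: the limit of > 150000 nM in this assay, at which 2 of the 4 values shown sit.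

The compounds shown leave open whether an amine or a carboxylic acid in place of that hydroxy would also give a measured number. They also leave open how a longer chain carrying the ethynyl group would compare with compound 3.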